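Moving One Methyl Where Two Compounds Sit at the Limit

This account rests on a few compounds, and the source may have more. Where it says the series, first, only, none or still open, it means among the compounds named here.

Compound 2 `Cc1cccc(NN=C2CCC(C)n3c2ncc(C(=O)O)c3=O)c1C` reaches only a limit in a functional assay on the whole organism with Rattus norvegicus as the target (on this read-out lower numbers stand for an effect already at smaller amounts and higher numbers for an effect only at larger amounts of compound), where compound 2 gives > 100 umol/kg. Compound 1 `CC1CCC(=NNc2ccccc2C(=O)O)c2ncc(C(=O)NO)c(=O)n21` also reaches only a limit in this assay, with compound 1 at > 100 umol/kg. Both values therefore sit at the limit of > 100 umol/kg in this assay, at which 2 of the 2 values shown sit. Compound 3 `Cc1cccc(C)c1NN=C1CCC(C)n2c1ncc(C(=O)O)c2=O` differs from compound 2 by 2,6-dimethylphenyl in place of 2,3-dimethylphenyl on an amine nitrogen. Within the data shown here, with no measured step between related compounds to draw on, the account expects compound 3 to remain near that limit, so that a step that the limit leaves unreadable from compound 2 to compound 3 is expected to be nothing beyond the scatter. Compound 3 is estimated at 150 umol/kg, within 50 umol/kg to 1000 umol/kg, and most likely reported again as a limit.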

Compound 3, dose for 50% inhibition: 320 umol/kg
Compound 3: middle estimate off by 2.1-fold (0.33 log units), on the low side, and the stated range covers the measured number.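

No size can be read for the step between compound 2 and compound 3, since the value of compound 2 is only a limit: the limit of > 100 umol/kg in this assay, at which 2 of the 3 values shown sit.

The compounds shown leave open whether 2,6-dimethylphenyl in place of 2,3-dimethylphenyl changes the dose required at all.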